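The compounds below may be only part of what the source reports. "The series", "measured", "known", "first", "only" and "open" are said of these compounds alone.

Measured so far:
Compound 1 `COCn1c(CC(COCc2ccccc2)COCc2ccccc2)cc(=O)[nH]c1=O`: > 100000 nM, which is a limit of the assay and not a number.
Compound 2 `COCn1c(CC(COCc2ccccc2)COCc2ccccc2)c(C)c(=O)[nH]c1=O`: 72600 nM.
Compound 3 `COCn1c(CC(COCc2ccccc2)COCc2ccccc2)c(C)c(=O)n(COC)c1=O`: 400 nM.

In a functional assay on MCF7 cells (Homo sapiens) for antiproliferative activity, read by MTT assay, with a stated time of 72 h (a lower number here means a stronger inhibitor, a higher number a weaker inhibitor), compound 2 stands at the highest of the two numbers, with compound 3 the nearest: a 180-fold lower number from compound 2 to compound 3 (2.26 log units; beyond the scatter). Compound 4 `COCn1c(CC(O)COCc2ccccc2)c(C)c(=O)[nH]c1=O` differs from compound 2 by hydroxy in place of (benzyloxy)methyl on a saturated chain carbon bound to two saturated chain carbons. Neither measured step matches this change: an at least 1.3-fold lower number from compound 1 to compound 2 (0.13 log units; that floor lies within the scatter) and a 180-fold lower number from compound 2 to compound 3 (2.26 log units; beyond the scatter) concern other places on the shared core. Among the measured compounds shown here, with no comparable step, the expected shift for compound 4 is a 1.7-fold higher number from compound 2 to compound 4 (0.22 log units; within the scatter), a modest weakening that may still fall within the scatter. Compound 4 is therefore estimated at 120000 nM, with a range from 35000 nM to 400000 nM, and a fair chance that only a limit is reported.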

Compound 4, half-maximal inhibitory concentration: > 100000 nM
Compound 4: a limit, no number; the forecaster's own chance of this, stated with the estimate: 55%; the middle value is on the limit's open side.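

The earlier steps shown here concerned other places on the shared core, while this one changes the chain itself. Hydroxy in place of (benzyloxy)methyl gives an at least 1.3-fold higher number from compound 2 to compound 4 (0.13 log units; that floor lies within the scatter), so only a floor is known, and it cannot show whether the group matters here. Compound 4 gives > 100000 nM in this assay, which is a limit and not a number: the limit of > 100000 nM in this assay, at which 2 of the 4 values shown sit.

On these data alone, whether an amine or a longer chain at this carbon would give a number remains open. So does the effect of methoxymethyl on the aromatic nitrogen of compound 4.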